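Compound 2 and a Benzyl-Triazolyl Replacement for the Dioxolanyl Group

The source may report more compounds than this note shows. Statements on the series, on what has been measured and on what is new or still open speak of the compounds shown alone.

Compound 2 `CNc1ncc2c(-c3ccc(N4CCNCC4)nc3)nn(CC3OCCO3)c2n1` was examined in an assay for inhibition of tyrosine-protein kinase receptor TYRO3 (Homo sapiens), read by 33P incorporation, in the presence of a further agent that is not named here; on this read-out higher numbers stand for weaker inhibition and lower numbers for stronger inhibition. In this assay compound 2 gives only a limit, > 10000 nM. Its measured neighbours are compound 1 `CNc1ncc2c(-c3ccc(N4CCNCC4)nc3)nn(CC3CCCC3)c2n1` and compound 3 `CNc1ncc2c(-c3ccc(OC)cc3)nn(CC3OCCO3)c2n1`. In this assay compound 1 gives a limit, > 10000 nM. In this assay compound 3 likewise gives a limit, > 10000 nM. All three rest on (the limit of > 10000 nM in this assay, at which 3 of the 3 values shown sit), so none of them can be placed apart from the others on the numbers shown. Within the data shown here, the single step between measured compounds that differ in one place, a step that the two limits leave unreadable from compound 1 to compound 2, cannot be read for the same reason.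

Compound 4 `CNc1ncc2c(-c3ccc(N4CCNCC4)nc3)nn(Cc3cn(Cc4ccccc4)nn3)c2n1` departs from compound 2 by 1-benzyl-1H-1,2,3-triazol-4-yl in place of 1,3-dioxolan-2-yl on a saturated chain carbon bound to an aromatic nitrogen. Among the measured compounds shown here, no measured step bears directly on this change; the only step recorded, from the cyclopentyl to the dioxolanyl group, left no readable size. The expectation for compound 4 therefore rests on the fact that every compound shown sits at the limit, and a step of an at least 1.2-fold lower number from compound 2 to compound 4 (0.09 log units; that floor lies within the scatter) is expected, meaning most likely no change beyond the scatter. Compound 4 is expected to give about 8000 nM in this assay, within 1500 nM to 30000 nM, with a fair chance that only a limit is reported once more.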

Compound 4, half-maximal inhibitory concentration: > 10000 nM
Compound 4: no number, only a limit; the forecaster's own chance of this, stated with the estimate: 70%; at least 1.2-fold (0.09 log units) between middle value and limit.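

In this assay compound 4 gives only a limit, > 10000 nM. The steps to compound 4 from compound 2 and from compound 1 therefore cannot be read: the limit of > 10000 nM in this assay, at which 4 of the 4 values shown sit.

The compounds shown leave open how the cyclopentyl, 1,3-dioxolan-2-yl and 1-benzyl-1H-1,2,3-triazol-4-yl groups rank against one another in this assay, and whether any group at that place gives a measured number.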